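A few compounds are considered here, and "the series" means these few. Any claim that something is new, unique, unknown or untested is made for them only; others in the source may bear on it.

Among the measured compounds shown here, compound 2 `Cc1cccc(Nc2nc(N)nc(COc3ccc4c(C)cc(=O)oc4c3)n2)c1` gives 1780 nM in an assay on COS-7 cells for agonist activity at Free fatty acid receptor 1 (Homo sapiens), read by scintillation counting and inositol phosphate accumulation, with a stated time of 90 min (a higher number here means that more compound is needed for the effect, a lower number that less compound is needed), the lowest of the two numbers measured so far; compound 1 `Cc1cc(=O)oc2cc(OCc3nc(N)nc(Nc4ccc(F)cc4)n3)ccc12` gives 18300 nM. For the measured compounds named here, the single measured step, a 10-fold lower number from compound 1 to compound 2 (1.01 log units; beyond the scatter), is large. Compound 3 `Cc1cc(=O)oc2cc(OCc3nc(N)nc(Nc4ccc(C5CC5)cc4)n3)ccc12` differs from compound 2 by 4-cyclopropylphenyl in place of 3-methylphenyl on a nitrogen on an aromatic ring. Going by the values given here, no measured step exchanges 3-methylphenyl for 4-cyclopropylphenyl directly; the only guide is that the 4-fluorophenyl analogue, compound 1, sits far higher than compound 2, so a modest rise in the number is expected on moving to compound 3, a 2.0-fold higher number from compound 2 to compound 3 (0.29 log units; within the scatter), with wide uncertainty. Compound 3 is estimated at 3500 nM in this assay, between 1000 nM and 12000 nM.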

Compound 3, half-maximal effective concentration: 700 nM
Compound 3: the middle estimate sits 5.0-fold (0.70 log units) above what was measured; measured number below the stated range.
By their numbers in this assay, from the lowest: compound 3; then compound 2; then compound 1.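

In this assay, among the compounds shown here, 4-cyclopropylphenyl on the nitrogen gives the lowest number of the series so far (a 2.5-fold lower number from compound 2 to compound 3 (0.41 log units; beyond the scatter)). With only the group on the aromatic carbon changed, cyclopropyl in place of fluoro gives a far larger drop (a 26-fold lower number from compound 1 to compound 3 (1.42 log units; beyond the scatter)), so this substituent strongly shifts the number. No measurement here explains the drop.

Compound 2 and compound 3 differ in both the group and its place on the phenyl ring, so 4-methylphenyl would be needed to separate the two. From the compounds shown here alone, whether tert-butyl, methoxy or an amine in that place goes lower remains open.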